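Swapping iodo for furan-3-yl in a weakly active series

The source may report more compounds than this note shows. Statements on the series, on what has been measured and on what is new or still open speak of the compounds shown alone.

Compound 1, `Cc1ncnc2c1c(I)cn2[C@@H]1O[C@H](CO)[C@@H](O)[C@H]1O`, in an ADME assay on MRC5 cells (Homo sapiens), read by MTT assay, with a stated time of 72 h (a lower number here means a stronger inhibitor, a higher number a weaker inhibitor), gives 13300 nM.
Compound 2, `CNc1ncnc2c1c(I)cn2[C@@H]1O[C@H](CO)[C@@H](O)[C@H]1O`, in this assay gives > 100000 nM, which is a limit of the assay and not a number.
Compound 3, `COc1ncnc2c1c(I)cn2[C@@H]1O[C@H](CO)[C@@H](O)[C@H]1O`, in this assay gives 63000 nM.

Compound 2 therefore stands at the weak end of the three, being the only one reported as the limit of > 100000 nM in this assay, at which 1 of the 3 values shown sits. Compound 4, `CNc1ncnc2c1c(-c1ccoc1)cn2[C@@H]1O[C@H](CO)[C@@H](O)[C@H]1O`, differs from it in one place: furan-3-yl in place of iodo on an aromatic carbon. The measured steps all change the group on the other ring: an at least 7.5-fold higher number from compound 1 to compound 2 (0.87 log units; beyond the scatter), a 4.7-fold higher number from compound 1 to compound 3 (0.68 log units; beyond the scatter), and an at least 1.5-fold lower number from compound 2 to compound 3 (0.20 log units; that floor lies within the scatter). Among the compounds with values here, none of them touches the iodo, so no measured step bears on the change to furan-3-yl, and there is no basis for expecting a step beyond the scatter in either direction in this assay. Compound 4 is expected to give about 100000 nM, in a range from 30000 nM to 300000 nM. That corresponds to an expected a number no higher from compound 2 to compound 4 (the limit leaves the size open), with a real chance that only a limit is reported again.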

Compound 4, half-maximal inhibitory concentration: > 100000 nM
Compound 4 gave a limit, no number; the forecaster's own chance of this, stated with the estimate: 60%; the middle value sits exactly at the limit.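

Within the data shown here, compound 2 and compound 4 both stop at the same limit of the assay rather than giving numbers, so no step between them can be read: the limit of > 100000 nM in this assay, at which 2 of the 4 values shown sit. The compounds shown leave open whether furan-3-yl in place of iodo changes activity in this assay at all.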